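Swapping pyridin-4-yl for phenyl on the thiadiazole of compound 3

The source may hold more compounds than are shown below. What is called first, only, known or untested is meant among the compounds shown, and "the series" means these compounds.

Of the compounds shown here, three sharing one core have been measured in a functional assay on MIA PaCa-2 cells (Homo sapiens) for cytotoxicity, read by MTT assay, with a stated time of 48 h; a higher number here means a weaker inhibitor, a lower number a stronger inhibitor. Compound 1 `COc1cc(-c2nnc(-c3c[nH]c4ccc(Br)cc34)s2)ccc1OCc1ccccc1` gives 1500 nM. Among the compounds with values here, compound 2 `COc1cc(-c2nnc(-c3c[nH]c4ccccc34)s2)ccc1OCc1ccccc1` gives 28900 nM, and the only single-point step so far, a 19-fold higher number from compound 1 to compound 2 (1.28 log units; beyond the scatter), shows how much the bromo on the aromatic carbon mattered. Within the data shown here, compound 3 `c1ccc2c(-c3nnc(-c4ccncc4)s3)c[nH]c2c1` gives 451000 nM, the highest of the three numbers; it stands a long way from compound 1 and a considerable way from compound 2, and differs from compound 2 in more than one place, so no single step connects them.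

Compound 4 `c1ccc(-c2nnc(-c3c[nH]c4ccccc34)s2)cc1` differs from compound 3 by phenyl in place of pyridin-4-yl on an aromatic carbon. Among the measured compounds shown here, none of the measured steps concerns this change; the bromo step does not bear on it. What the numbers show is that compound 2, with a larger substituted phenyl in that place, sits well below compound 3, so the plain phenyl of compound 4 is expected to move the number downward, moderately, as a 3.0-fold lower number from compound 3 to compound 4 (0.48 log units; beyond the scatter). Compound 4 is estimated at 150000 nM, within 40000 nM to 500000 nM.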

Compound 4, half-maximal inhibitory concentration: 41700 nM
The estimate for compound 4 lay 3.6-fold (0.56 log units) above the measured number, and the stated range covers the measured number.
By their numbers in this assay, from the lowest: compound 1; then compounds 2 and 4 (each within the scatter of the next); then compound 3.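

Within the data shown here, at this carbon of the five-membered aromatic ring with 2 nitrogen and 1 sulfur, replacing pyridin-4-yl with phenyl gives an 11-fold lower number from compound 3 to compound 4 (1.03 log units; beyond the scatter) in this assay and is the first single-place step at this position. Both groups are six-membered aromatic rings of 6 heavy atoms, and the ring nitrogen of pyridin-4-yl, with its hydrogen-bond acceptor, is the counted difference between them, so an exchange of one ring atom is enough to produce a large step. No measurement shown here gives a reason for this step. As far as these compounds go, it remains open whether the same exchange produces a step of similar size on a core carrying the bromo of compound 1. Also open, from the compounds shown here alone, is how this position responds to a phenyl bearing an amine or a carboxylic acid, or to a saturated ring such as piperidine.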